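A Third Methoxy Group and Cell Growth Inhibition

This account rests on a few compounds, and the source may have more. Where it says the series, first, only, none or still open, it means among the compounds named here.

Of the compounds shown here, three have been measured in a functional assay on HCC 2998 cells (Homo sapiens) for inhibition, read by sulforhodamine B assay, with a stated time of 48 h; a higher number here means a weaker inhibitor of growth, a lower number a stronger inhibitor of growth. Compound 1 `COc1ccc(-c2cc(/C=C/C(=O)c3ccc(N)cc3)[nH]n2)cc1` gives 1830 nM in this assay, compound 3 `COc1ccc(-c2cc(/C=C/C(=O)c3ccc(N)cc3)[nH]n2)cc1OC` gives 2020 nM, and compound 2 `COc1ccc(C(=O)/C=C/c2cc(-c3cc(OC)c(OC)c(OC)c3)n[nH]2)cc1OC` gives 2130 nM. Compounds 1 and 3 differ in one place only, (methoxy in place of hydrogen on an aromatic carbon). The difference between the core of compound 1 and the core of compound 2 is not broken down here; all three values sit within the scatter of one another, so no order among them can be read.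

Compound 4 `COc1cc(C(=O)/C=C/c2cc(-c3cc(OC)c(OC)c(OC)c3)n[nH]2)cc(OC)c1OC` has not yet been measured. It differs from compound 2 by methoxy in place of hydrogen on an aromatic carbon. This is the same kind of change as that from compound 1 to compound 3, though not the same: in compound 4 the place is in addition meta to a methoxy group. Because a 1.1-fold higher number from compound 1 to compound 3 (0.04 log units; within the scatter) stayed within the scatter, the step from compound 2 to compound 4 is expected to be similar, a 1.1-fold higher number from compound 2 to compound 4 (0.03 log units; within the scatter) in this assay. Compound 4 is therefore estimated to give about 2300 nM, expected to fall between 1100 nM and 4800 nM.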

Compound 4, concentration for 50% growth inhibition: 1830 nM
For compound 4 the middle estimate is 1.3-fold (0.10 log units) above the measured one; the range from low to high includes it.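

In this assay, methoxy in place of hydrogen on an aromatic carbon gives a 1.2-fold lower number from compound 2 to compound 4 (0.07 log units; within the scatter). Set side by side, the two steps cannot be told apart: the same change on two cores in this assay, a 1.1-fold higher number (0.04 log units; within the scatter) from compound 1 to compound 3 and a 1.2-fold lower number (0.07 log units; within the scatter) from compound 2 to compound 4, 1.3-fold (0.11 log units) apart, within the scatter of two such steps. This shows that on neither the core of compound 1 nor the core of compound 2 does the change produce a step that stands out from the scatter, and that the result on one core gave no sign of a different result on the other; it does not show that a real effect of a given size or direction carries over, as both steps are too small to be read and the opposite directions of the printed numbers mean nothing.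

The compounds shown leave open whether a different group at this place, such as a carboxylic acid, a hydroxyl or a longer chain like ethoxy, would move the value beyond the scatter. They also leave open whether methoxy would matter on a core where the values are spread more widely.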